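The source may hold more compounds than are shown below. What is called first, only, known or untested is meant among the compounds shown, and "the series" means these compounds.

Compound 1, with the structure `Cn1ncc(Cl)c1-c1cc(C(=O)N[C@@H]2CN[C@H](CC(O)CO)C[C@H]2c2ccc(Cl)c(Cl)c2)oc1Cl`, is the stronger of the two measured compounds here: in a functional assay on LNCaP cells (Homo sapiens) for antiproliferative activity (a higher number here means a weaker inhibitor, a lower number a stronger inhibitor), compound 1 gives 70 nM, the lowest of the two numbers on hand. Within the data shown here, its only measured neighbour is compound 2, `CN(C)CC[C@@H]1C[C@@H](c2ccc(Cl)c(Cl)c2)[C@H](NC(=O)c2cc(-c3c(Cl)cnn3C)c(Cl)o2)CN1`, which in this assay gives 1930 nM; the step of a 28-fold higher number from compound 1 to compound 2 (1.44 log units; beyond the scatter) is large and well beyond the scatter, and it comes from a (dimethylamino)methyl in place of 1,2-dihydroxyethyl on a saturated chain carbon bound to a saturated ring carbon.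

Compound 3, `Cn1ncc(Cl)c1-c1cc(C(=O)N[C@@H]2CN[C@H](CC(=O)NCC(O)CO)C[C@H]2c2ccc(Cl)c(Cl)c2)oc1Cl`, is not yet measured. It differs from compound 1 by (2,3-dihydroxypropyl)carbamoyl in place of 1,2-dihydroxyethyl on a saturated chain carbon bound to a saturated ring carbon. Among the measured compounds shown here, the one measured step concerns the same place but a different entering group, one carrying a basic amine, so it does not bear directly on compound 3, whose entering group is uncharged and keeps hydroxy groups while growing by an amide. For the measured compounds named here, with no direct precedent, a modest loss is expected, within or only slightly beyond the scatter, as a 2.1-fold higher number from compound 1 to compound 3 (0.33 log units; beyond the scatter). Compound 3 is therefore estimated at 150 nM, in a range from 45 nM to 500 nM.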

Compound 3, half-maximal inhibitory concentration: 660 nM
Compound 3: middle estimate off by 4.4-fold (0.64 log units), on the low side; the measured number lies above the stated range.
By their numbers in this assay, from the lowest: compound 1; then compound 3; then compound 2.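

Compound 2 had left open whether the loss at this position belonged to a group carrying an amine, but compound 3 shows that a replacement with no net charge that keeps its hydroxy groups also loses activity in this assay: (2,3-dihydroxypropyl)carbamoyl in place of 1,2-dihydroxyethyl gives a 9.4-fold higher number from compound 1 to compound 3 (0.97 log units; beyond the scatter). The two replacements are not equivalent, since (2,3-dihydroxypropyl)carbamoyl in place of (dimethylamino)methyl on the same saturated chain carbon gives a 2.9-fold lower number from compound 2 to compound 3 (0.47 log units; beyond the scatter), which places compound 3 between the other two and leaves compound 1 the strongest of the three. Nothing on hand accounts for either step, so the reason for these differences remains unexplained.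

The compounds shown leave open which part of the (2,3-dihydroxypropyl)carbamoyl group carries the loss, the amide or the longer chain beyond it, and a simple primary amide or a carboxylic acid at this position would separate these. They also leave open whether a shorter diol or a single hydroxymethyl group would match or improve on 1,2-dihydroxyethyl on the shared core.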